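Inverting one ring stereocentre in a glycoside pair

This account rests on a few compounds, and the source may have more. Where it says the series, first, only, none or still open, it means among the compounds named here.

Measured so far:
compound 1, `CO[C@H]1O[C@H](COc2ccc(C3CCCCC3)cc2)[C@@H](O)[C@H](O)[C@H]1Oc1ccc(OC2CCCCC2)cc1`: 12000 nM
compound 2, `CO[C@@H]1O[C@H](COc2cccc(C(C)C)c2)[C@@H](O)[C@H](O)[C@H]1Oc1ccc(OC2CCCCC2)cc1`: 41000 nM

Among the compounds with values here, in a functional assay on A549 cells (Homo sapiens) for cytotoxicity, read by MTT assay, with a stated time of 48 h (on this read-out higher numbers stand for an effect only at larger amounts of compound and lower numbers for an effect already at smaller amounts), compound 2 gives 41000 nM, the higher of the two numbers known; compound 1 lies below it in this assay by a gap beyond the usual scatter, and compound 1 also differs from compound 2 in more than one place, so no single step can be read from that pair.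

Compound 3, `CO[C@H]1O[C@H](COc2cccc(C(C)C)c2)[C@@H](O)[C@H](O)[C@H]1Oc1ccc(OC2CCCCC2)cc1`, is the next compound for this assay. It is related to compound 2 as follows: the two compounds have the same atoms and bonds and differ only in configuration as drawn: 1 of 5 stereo elements differ; a stereocentre at a saturated ring carbon is drawn R in compound 2 and S in compound 3.

Within the data shown here, no step between measured compounds isolates such an inversion, so its size is open. Compound 1 carries the same drawn configuration at that centre and gives 12000 nM, which is the only hint that this configuration is tolerated. The step from compound 2 to compound 3 is expected to be small, a 1.5-fold lower number from compound 2 to compound 3 (0.17 log units; within the scatter), possibly within the scatter. Compound 3 is thus estimated at 28000 nM, with a range from 9000 nM to 80000 nM.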

Compound 3, half-maximal effective concentration: 30000 nM
Estimate against measurement, compound 3: 1.1-fold (0.03 log units) below; low and high end bracket the measured number.
By their numbers in this assay, from the lowest: compound 1; then compounds 3 and 2 (each within the scatter of the next).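

In this assay, inverting the stereocentre at the saturated ring carbon gives a 1.4-fold lower number from compound 2 to compound 3 (0.14 log units; within the scatter), so with 3-isopropylphenyl in place, the R and S drawings cannot be told apart on this read-out. This pair isolates the stereocentre alone, with no other structural change involved: the fact that compounds 2 and 3 differ only in the configuration as drawn. With that configuration held, the aryl group can also be read as a single change, 3-isopropylphenyl in place of 4-cyclohexylphenyl giving a 2.5-fold higher number from compound 1 to compound 3 (0.40 log units; beyond the scatter), a step that, unlike the inversion, lies beyond the scatter.

From the compounds shown here alone, it remains open whether the inversion stays within the scatter when 4-cyclohexylphenyl is present. Also open, going by these compounds, is how the number responds when a carboxylic acid or an amine takes the place of the isopropyl group.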